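Fluorine Loss on a Fused Heteroaromatic in Hepatoma Cells

The source may report more compounds than this note shows. Statements on the series, on what has been measured and on what is new or still open speak of the compounds shown alone.

Three compounds sharing a dibenzyloxy core were tested in a functional assay on HepG2 cells (Homo sapiens) for antiproliferative activity, read by MTT assay, with a stated time of 72 h; on this read-out higher numbers stand for weaker inhibition and lower numbers for stronger inhibition. Compound 1 `O=C1NC(O)(/C=C\n2cc(I)c3c(Cl)ncnc32)C(OCc2ccccc2)=C1OCc1ccccc1` gives 32400 nM in this assay. Compound 3 `O=C1NC(O)(CCn2cnc3cncc(Br)c32)C(OCc2ccccc2)=C1OCc1ccccc1` gives 66500 nM in this assay. Compound 2 `O=C1O/C(=C\Cn2cnc3c(F)nc(F)c(Cl)c32)C(OCc2ccccc2)=C1OCc1ccccc1` reaches only a limit of this assay, > 100000 nM, not a number. The relevant line reads (the limit of > 100000 nM in this assay, at which 1 of the 3 values shown sits). Going by the values given here, no step between measured compounds is available, so no measured change can be set against the scatter. Compound 4 `O=C1O/C(=C\Cn2cnc3ccnc(Cl)c32)C(OCc2ccccc2)=C1OCc1ccccc1` differs from compound 2 in one place: a group of 10 heavy atoms (6 carbon, 3 nitrogen, 1 chlorine; one five-membered aromatic ring with 2 hetero atoms, one six-membered aromatic ring with 1 hetero atom) in place of a group of 12 heavy atoms (6 carbon, 3 nitrogen, 2 fluorine, 1 chlorine; one five-membered aromatic ring with 2 hetero atoms, one six-membered aromatic ring with 1 hetero atom), on a saturated chain carbon bound to a double-bonded chain carbon. Since compound 2 stands at a limit, only a weak direction can be expected. Compound 4 is expected near 70000 nM, within 30000 nM to 150000 nM. The expected step of an at least 1.4-fold lower number from compound 2 to compound 4 (0.15 log units; that floor lies within the scatter) is estimated as small, toward somewhat stronger inhibition.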

Compound 4, half-maximal inhibitory concentration: > 100000 nM
Compound 4 was reported as a limit; the forecaster's own chance of this, stated with the estimate: 40%; at least 1.4-fold (0.15 log units) between middle value and limit.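

Going by these compounds alone, compound 2 and compound 4 each stand at a limit in this assay, not at a number, and no step between them can be read. Going by these compounds, whether the loss of both fluorine atoms changes inhibition at all remains open.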